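A few compounds are considered here, and "the series" means these few. Any claim that something is new, unique, unknown or untested is made for them only; others in the source may bear on it.

Compound 1 `CC(C)c1n[nH]c2c(NCc3ccc(-c4ccccn4)cc3)nc(SCC(N)=O)nc12` stands at the highest of the three numbers measured in a functional assay on HT cells (Homo sapiens) for antiproliferative activity, read by fluorescence, with a stated time of 72 h (a lower number here means a stronger inhibitor of growth, a higher number a weaker inhibitor of growth), where compound 1 gives 192 nM. Compound 2 `CNCCSc1nc(NCc2ccc(-c3ccccn3)cc2)c2[nH]nc(C(C)C)c2n1` gives 56 nM, and compound 3 `CC(C)c1n[nH]c2c(NCc3ccc(-c4ccccn4)cc3)nc(SCCn3ccnc3)nc12` gives 155 nM. Compound 4 `CC(C)c1n[nH]c2c(NCc3ccc(-c4ccccn4)cc3)nc(SCC(O)CN3CCNCC3)nc12` differs from compound 1 in one place: 1-hydroxy-2-(piperazin-1-yl)ethyl in place of carbamoyl on a saturated chain carbon bound to a sulfur. Among the measured compounds shown here, two measured steps bear on this change. The step of a 3.4-fold lower number from compound 1 to compound 2 (0.54 log units; beyond the scatter) shows a modest gain when methylamino enters, whereas the step of a 1.2-fold lower number from compound 1 to compound 3 (0.09 log units; within the scatter) shows nothing beyond the scatter when imidazol-1-yl enters. The expectation leans toward compound 2 because of a 3.4-fold lower number from compound 1 to compound 2 (0.54 log units; beyond the scatter) and the piperazin-1-yl ring that enters here. The expected step is a 2.6-fold lower number from compound 1 to compound 4 (0.41 log units; beyond the scatter). Compound 4 is therefore estimated to give 75 nM in this assay, within a range of 30 nM to 190 nM.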

Compound 4, concentration for 50% growth inhibition: 332 nM
Beside the measured number, compound 4's estimate is 4.4-fold (0.65 log units) below it, and the stated range ends below it.
By their numbers in this assay, from the lowest: compound 2; then compounds 3, 1 and 4 (each within the scatter of the next, the first and the last beyond it).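

In this assay, the 2-hydroxy-3-(piperazin-1-yl)propyl chain on the sulfur brings no gain over carbamoylmethyl, with a 1.7-fold higher number from compound 1 to compound 4 (0.24 log units; within the scatter). A basic-free reading of the names alone is not enough here: an amine nitrogen in the chain does not by itself hold the level of compound 2, as a 5.9-fold higher number from compound 2 to compound 4 (0.77 log units; beyond the scatter) shows, and the new group also falls short of the imidazole-bearing chain, with a 2.1-fold higher number from compound 3 to compound 4 (0.33 log units; beyond the scatter). Nothing measured here explains these steps.

On these data alone, the hydroxyl and the piperazine ring enter together, so their separate contributions remain open. A 3-(piperazin-1-yl)propyl chain without the hydroxyl, or a morpholine ring in place of the piperazine, would tell them apart.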